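Benzamido gives way in compound 3

The compounds below may be only part of what the source reports. "The series", "measured", "known", "first", "only" and "open" are said of these compounds alone.

In an ADME assay on cells (Hepatocyte, Mus musculus) for metabolic stability, with a stated time of 30 min (a higher number here means that more of the compound is left, a lower number that less of the compound is left), compound 1 `NC1CCC(CN2CCN(c3cc(=O)c4cc(C(F)(F)F)cc([N+](=O)[O-])c4s3)CC2)CC1` gives 107% and compound 2 `CS(=O)(=O)NC1CCC(CN2CCN(c3cc(=O)c4cc(C(F)(F)F)cc([N+](=O)[O-])c4s3)CC2)CC1` gives 111% while compound 3 `O=C(NC1CCC(CN2CCN(c3cc(=O)c4cc(C(F)(F)F)cc([N+](=O)[O-])c4s3)CC2)CC1)c1ccccc1` stands at 90.6% as the lowest of the three. Going by the values given here, compound 4 `Cc1ccc(C(=O)OC2CCC(CN3CCN(c4cc(=O)c5cc(C(F)(F)F)cc([N+](=O)[O-])c5s4)CC3)CC2)cc1` carries ((4-methylphenyl)carbonyl)oxy in place of benzamido on a saturated ring carbon and no measured step makes this same change. The closest evidence is indirect. Benzoyl in place of hydrogen on an amine nitrogen gave a number 16.4 percentage points lower from compound 1 to compound 3 (beyond the scatter) and benzoyl in place of methylsulfonyl gave a number 20.4 percentage points lower from compound 2 to compound 3 (beyond the scatter) while methylsulfonyl in place of hydrogen gave a number 4 percentage points higher from compound 1 to compound 2 (within the scatter) in comparison. On that basis, a modest downward step is expected, estimated as a number 18.6 percentage points lower from compound 3 to compound 4 (beyond the scatter) in this assay with wide uncertainty. The estimate for compound 4 is 72% (range 40% to 100%).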

Compound 4, percent of the compound remaining: 18%
Beside the measured number, compound 4's estimate is 54 percentage points above it; measured number outside the range, below it.
By their numbers in this assay, from the lowest: compound 4; then compound 3; then compounds 1 and 2 (each within the scatter of the next).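

In this assay the ((4-methylphenyl)carbonyl)oxy group on the saturated ring carbon gave a number 72.6 percentage points lower from compound 3 to compound 4 (beyond the scatter) and also a number 93 percentage points lower from compound 2 to compound 4 (beyond the scatter) and a number 89 percentage points lower from compound 1 to compound 4 (beyond the scatter) as its other two steps. Amino, methanesulfonamido and benzamido at this position differed by modest steps at most, so this result shows that the position is not indifferent to its substituent: benzamido and the entering group both carry a six-membered aromatic ring of carbon only, yet their compounds stand far apart. As far as these compounds go, how a benzoyloxy group or a ((4-methylphenyl)carbonyl)amino group would stand remains open, so the share of the oxygen link and that of the methyl cannot be separated. No measurement shown here accounts for the drop.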